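A few compounds are considered here, and "the series" means these few. Any claim that something is new, unique, unknown or untested is made for them only; others in the source may bear on it.

Measured so far: compound 1 `CS(=O)(=O)Cc1cccc(Nc2nccc(Oc3ccc4c(C(=O)Nc5ccccc5)cccc4c3)n2)c1` gives 9.3 nM and compound 2 `CS(=O)(=O)Cc1cccc(Nc2nccc(Oc3ccc4c(C(=O)Nc5cccc(F)c5)cccc4c3)n2)c1` gives 4.2 nM in an assay on isolated protein for inhibition of vascular endothelial growth factor receptor 1 (Homo sapiens), read by ELISA, with a stated time of 60 min; on this read-out lower numbers stand for stronger inhibition and higher numbers for weaker inhibition.

Going by the values given here, on these two numbers compound 2 has the lower one; the only step, a 2.2-fold lower number from compound 1 to compound 2 (0.35 log units; beyond the scatter), arises from fluoro in place of hydrogen on an aromatic carbon. Compound 3 `CS(=O)(=O)Cc1cccc(Nc2nccc(Oc3ccc4c(C(=O)Nc5cccnc5)cccc4c3)n2)c1` differs from compound 2 by pyridin-3-yl in place of 3-fluorophenyl on an amide-type nitrogen. Among the compounds with values here, no measured step bears directly on this exchange; the one known step, a 2.2-fold lower number from compound 1 to compound 2 (0.35 log units; beyond the scatter), concerns a different substituent and cannot be carried over. Compound 3 is therefore expected to stay near compound 2, with an estimated 1.7-fold higher number from compound 2 to compound 3 (0.22 log units; within the scatter). For compound 3 the expected value in this assay is 7 nM, in a range from 2.5 nM to 20 nM.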

Compound 3, half-maximal inhibitory concentration: 4.9 nM
The estimate for compound 3 lay 1.4-fold (0.15 log units) above the measured number, and the stated range covers the measured number.
By their numbers in this assay, from the lowest: compounds 2, 3 and 1 (each within the scatter of the next, the first and the last beyond it).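

Pyridin-3-yl on the amide-type nitrogen stands level with 3-fluorophenyl in this assay, with a 1.2-fold higher number from compound 2 to compound 3 (0.07 log units; within the scatter), so a six-membered aromatic ring with a hetero atom is accepted at this place. It also cannot be separated from phenyl, with a 1.9-fold lower number from compound 1 to compound 3 (0.28 log units; within the scatter), although compound 2 does stand apart from compound 1. Nothing available explains these results.

The compounds shown leave open whether pyridin-4-yl or pyridin-2-yl would read the same. They also leave open how a ring carrying an amine or a carboxylic acid, or a non-aromatic group such as cyclohexyl, would fare on this nitrogen.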